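A few compounds are considered here, and "the series" means these few. Any claim that something is new, unique, unknown or untested is made for them only; others in the source may bear on it.

Compound 1 `CNCC(=O)Nc1cc(OC)ccc1C(=O)c1cc(OC)c(OC)c(OC)c1`: 780 nM
Compound 2 `C=C(c1ccc(OC)cc1NC(=O)CN)c1ccc(OC)c2c1OC(C)(C)C=C2`: 190 nM
Compound 3 `C=C(c1ccc(OC)cc1NC(=O)CN)c1ccc(OC)c2c1C=CC(C)(C)O2`: 520 nM

These values come from a functional assay on HCT-8 cells (Homo sapiens) for antiproliferative activity, read by MTT assay, with a stated time of 48 h; on this read-out lower numbers stand for stronger inhibition and higher numbers for weaker inhibition. Compound 3, at 520 nM, lies within the usual scatter of compound 1, at 780 nM, so these two numbers cannot be told apart. Compound 2, at 190 nM, gives a lower number than compound 3, and that gap lies beyond the scatter.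

The next compound to be considered is compound 4 `C=C(c1ccc(OC)cc1NC(=O)CN(C)C)c1ccc(OC)c2c1C=CC(C)(C)O2`, which differs from compound 3 in one place: dimethylamino in place of amino on a saturated chain carbon bound to a carbonyl carbon. In words, dimethylamino stands in place of amino on a saturated chain carbon bound to a carbonyl carbon.

Among the measured compounds shown here, no measured pair in this set shows this change on its own, so the data give no direct size for it. In this assay, no step beyond the scatter is therefore expected, although a small move towards a higher number would not be a surprise. The estimated step is a 1.2-fold higher number from compound 3 to compound 4 (0.06 log units; within the scatter). With so little to go on, the expected range is kept wide. For compound 4 the estimated value is 600 nM, within an expected range of 180 nM to 2000 nM.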

Compound 4, half-maximal inhibitory concentration: 1920 nM
Estimate against measurement, compound 4: 3.2-fold (0.51 log units) below; the measured number falls inside the stated range.
By their numbers in this assay, from the lowest: compound 2; then compounds 3 and 1 (each within the scatter of the next); then compound 4.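

In this assay, among the compounds shown here, the read-out shows a 3.7-fold higher number from compound 3 to compound 4 (0.57 log units; beyond the scatter) when dimethylamino stands in place of amino on a saturated chain carbon bound to a carbonyl carbon, which gives the first direct reading of this position. The earlier compounds shown here offered no single-place pair, whereas this one shows that the group at this position is not interchangeable on this core: the step runs towards weaker inhibition and lies beyond the usual scatter. The change removes the hydrogen-bond donor counted on amino and adds two carbon atoms, but nothing supplied with the result says which of these differences, if either, accounts for the step.

Going by these compounds, this remains a single pair on a single core, so it is open whether the same replacement would give a step of similar size on the core of compound 2, whose amino group sits on the same saturated chain carbon. On these data alone, it is also open how a pyrrolidine ring, a piperidine ring or a hydroxyl group at this position would compare with amino and dimethylamino in this assay.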